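Thiophene isomer swap on the cyclohexyl ester compound

The source may report more compounds than this note shows. Statements on the series, on what has been measured and on what is new or still open speak of the compounds shown alone.

Measured compounds:
compound 1 `CC(=O)C1=C(C)NC(=O)NC1c1ccsc1`: in an assay on membranes from HEK293 cells for displacement of a labelled ligand from adenosine receptor A2b (Homo sapiens), read by scintillation counting, with a stated time of 30 min, tested at 1 uM (a lower number here means less inhibition, a higher number more inhibition at the concentration tested (going by the name of the read-out)), compound 1 gives 24%
compound 2 `CCSC(=O)C1=C(C)NC(=O)NC1c1ccsc1`: in this assay compound 2 gives 17%
compound 3 `CC1=C(C(=O)OC2CCCCC2)C(c2cccs2)NC(=O)N1`: in this assay compound 3 gives 3%

Compound 3 stands lowest of the three numbers in this assay; compound 2 is nearest to it and compound 1 furthest, and both gaps lie beyond the usual scatter. Within the data shown here, the one measured step within the set, a number 7 percentage points lower from compound 1 to compound 2 (within the scatter), concerns the carbonyl carbon and not the saturated ring carbon, so it does not bear directly on the change considered here.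

Compound 4 `CC1=C(C(=O)OC2CCCCC2)C(c2ccsc2)NC(=O)N1` differs from compound 3 only in thiophen-3-yl in place of thiophen-2-yl on a saturated ring carbon. Among the measured compounds shown here, no measured pair isolates this change. Compounds 1 and 2 carry the thiophen-3-yl group and give higher numbers than compound 3, but they also differ from compound 3 at the carbonyl carbon, so the thiophene contribution cannot be separated from that of the cyclohexyl ester. The expectation is therefore a step of a number 7 percentage points higher from compound 3 to compound 4 (within the scatter) that is small, upward if anything, and quite possibly within the scatter. Compound 4 is estimated at 10% in this assay, with a range from 0% to 25%.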

Compound 4, a percentage reported as inhibition, at one concentration (the size of the read-out at that concentration, not a potency): 4%
Beside the measured number, compound 4's estimate is 6 percentage points above it; low and high end bracket the measured number.
By their numbers in this assay, from the lowest: compounds 3 and 4 (each within the scatter of the next); then compounds 2 and 1 (each within the scatter of the next).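

In this assay the exchange of thiophen-2-yl for thiophen-3-yl on the saturated ring carbon next to the ring nitrogen can now be read on its own: with the cyclohexyl ester held constant there is a number 1 percentage points higher from compound 3 to compound 4 (within the scatter) and the two thiophene isomers are not told apart at this position. With thiophen-3-yl held constant, the group on the carbonyl carbon can also be read alone, with cyclohexyloxy in place of ethylsulfanyl giving a number 13 percentage points lower from compound 2 to compound 4 (beyond the scatter) and cyclohexyloxy in place of methyl giving a number 20 percentage points lower from compound 1 to compound 4 (beyond the scatter) so among these compounds the lower numbers go with the cyclohexyl ester and not with the thiophene isomer. Nothing at hand offers an explanation for any of these steps.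

From the compounds shown here alone, both cyclohexyl esters sit low in the range, with compound 3 at 3% and compound 4 at 4% so it remains open whether the thiophene exchange would also leave the number unmoved with methyl or ethylsulfanyl on the carbonyl carbon. Also open, going by these compounds, is how other groups would read at the two places, such as furan-3-yl or phenyl on the saturated ring carbon, or a methyl ester or an amide on the carbonyl carbon.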